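Replacing the nitrobenzoyl amide in the chromone series

This account rests on a few compounds, and the source may have more. Where it says the series, first, only, none or still open, it means among the compounds named here.

Measured so far:
compound 1 `O=C(COc1ccc2c(=O)ccoc2c1)Nc1cccc(NC(=O)c2ccccc2)c1`; in an assay on isolated protein for inhibition of Rho-associated protein kinase 1 (Homo sapiens), read by scintillation counting, radiometric assay and 33P incorporation, with a stated time of 40 min, in the presence of a further agent that is not named here (a higher number here means a weaker inhibitor, a lower number a stronger inhibitor), compound 1 gives 120 nM
compound 2 `O=C(COc1ccc2c(=O)ccoc2c1)Nc1cccc(NC(=O)c2ccc([N+](=O)[O-])cc2)c1`; in this assay compound 2 gives 67 nM

Compound 2 holds the lowest of the two numbers in this assay. Among the compounds with values here, its nearest neighbour is compound 1, and the only measured step, a 1.8-fold lower number from compound 1 to compound 2 (0.25 log units; within the scatter), lies within the scatter, so the two compounds are not separated by the data.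

Compound 3 `Cc1nc(C(=O)Nc2cccc(NC(=O)COc3ccc4c(=O)ccoc4c3)c2)cs1` differs from compound 2 in one place: 2-methyl-1,3-thiazol-4-yl in place of 4-nitrophenyl on a carbonyl carbon. Within the data shown here, no measured step bears directly on this exchange. Among the measured compounds shown here, the single step recorded, a 1.8-fold lower number from compound 1 to compound 2 (0.25 log units; within the scatter), concerns a substituent on the six-membered aromatic ring that now leaves entirely, and that step stayed within the scatter. Whether swapping the whole ring for the five-membered heterocycle shifts the number cannot be read from two compounds; nothing measured argues for a move beyond the scatter in either direction. The expected step is a 1.5-fold higher number from compound 2 to compound 3 (0.17 log units; within the scatter), in effect no change. Compound 3 is therefore estimated at 100 nM in this assay, with a range from 40 nM to 250 nM to cover the unknown ring exchange.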

Compound 3, half-maximal inhibitory concentration: 473 nM
For compound 3 the middle estimate is 4.7-fold (0.67 log units) below the measured one; the whole stated range lies below it.
By their numbers in this assay, from the lowest: compounds 2 and 1 (each within the scatter of the next); then compound 3.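

The group on this carbonyl carbon turns out not to be interchangeable: in this assay the exchange of 4-nitrophenyl for 2-methyl-1,3-thiazol-4-yl gives a 7.1-fold higher number from compound 2 to compound 3 (0.85 log units; beyond the scatter) and so separates two compounds in a way that the nitro step did not. Measured against the unsubstituted phenyl, the exchange gives a 3.9-fold higher number from compound 1 to compound 3 (0.60 log units; beyond the scatter) and is again beyond the scatter, so the rise in the number is not tied to the presence of the nitro group; in both available comparisons the six-membered carbon ring gives the lower number. No measurement on hand accounts for the size of these steps.

The exchange alters ring size, hetero atoms and the methyl group together, so the compounds shown leave open which of these changes carries the step. Also open, as far as these compounds go, are how 1,3-thiazol-4-yl without the methyl group or a pyridyl ring would read on this carbonyl carbon, and whether an amine or a carboxylic acid in place of the nitro group on the phenyl ring would move the number beyond the scatter.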